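The source may report more compounds than this note shows. Statements on the series, on what has been measured and on what is new or still open speak of the compounds shown alone.

Compound 3, `OCC(CO)OCn1c(S)nc2cc(Cl)c(Cl)cc21`, is known in a functional assay on KB cells (Homo sapiens) for inhibition (on this read-out higher numbers stand for weaker inhibition and lower numbers for stronger inhibition), only by a limit, > 100000 nM. Compound 1, `Nc1nc2cc(Cl)c(Cl)cc2n1COC(CO)CO`, likewise reaches only a limit in this assay, > 100000 nM. Compound 2, `CNc1nc2cc(Cl)c(Cl)cc2n1COC(CO)CO`, stands at a limit as well, > 100000 nM. Because all three sit at the limit of > 100000 nM in this assay, at which 3 of the 3 values shown sit, the steps a step that the two limits leave unreadable from compound 1 to compound 2, a step that the two limits leave unreadable from compound 1 to compound 3 and a step that the two limits leave unreadable from compound 2 to compound 3 cannot be sized. Compound 4, `OCC(CO)OCn1c(Br)nc2cc(Cl)c(Cl)cc21`, differs from compound 3 by bromo in place of sulfanyl on an aromatic carbon. For the measured compounds named here, none of the measured steps involves a bromo group, so no measured step bears on this change, and the limit values give no direction. Compound 4 is therefore expected to remain near the same limit, estimated at 100000 nM with a range from 20000 nM to 300000 nM. The expected step from compound 3 is a number no higher from compound 3 to compound 4 (the limit leaves the size open).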

Compound 4, half-maximal inhibitory concentration: > 100000 nM
Compound 4: no number, only a limit (the forecaster's own chance of this, stated with the estimate: 80%); the middle value sits exactly at the limit.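

For the compounds shown here, compound 4 sits at a limit, as do compound 1, compound 2 and compound 3, so no step among them can be read: the limit of > 100000 nM in this assay, at which 4 of the 4 values shown sit. The compounds shown leave open which group on this aromatic carbon, if any, would give a readable value in this assay.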